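One Chlorine Fewer: Estimating Compound 4

The compounds below may be only part of what the source reports. "The series", "measured", "known", "first", "only" and "open" are said of these compounds alone.

Compound 1 `COc1ccc(-c2ccnc(Nc3ccc(Cl)cc3Cl)n2)cc1`: 4170 nM
Compound 2 `O=[N+]([O-])c1ccc(Nc2nccc(-c3ccc(Cl)c(Cl)c3)n2)cc1`: 3510 nM
Compound 3 `O=[N+]([O-])c1ccc(Nc2nccc(-c3ccc(Br)cc3)n2)cc1`: 681000 nM

Of the compounds shown here, three have been measured in a functional assay on MCF7 cells (Homo sapiens) for antiproliferative activity, read by MTT assay; a higher number here means a weaker inhibitor, a lower number a stronger inhibitor. Compound 1 stands second highest of the three numbers. Its nearest neighbour is compound 2, whose value of 3510 nM lies within the scatter of that of compound 1, so no order between them can be claimed. Compound 3 is the furthest away, and its value of 681000 nM lies far beyond the scatter from compound 1.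

Compound 4 `COc1ccc(-c2ccnc(Nc3ccc(Cl)cc3)n2)cc1` has not yet been measured in this assay. Its difference from compound 1 is hydrogen in place of chloro on an aromatic carbon.

Within the data shown here, only one measured step is available, a 190-fold higher number from compound 2 to compound 3 (2.29 log units; beyond the scatter), and it concerns a change of halogen pattern on the other aromatic ring of the shared core, not the ring carrying the chloro group that is removed here. It bears on the new step only loosely, showing that losing halogen substitution can cost a great deal in this series. Among the measured compounds shown here, with no closer precedent, a moderate weakening is expected, a step of a 2.2-fold higher number from compound 1 to compound 4 (0.33 log units; beyond the scatter), with wide uncertainty.

Compound 4 is therefore estimated at 9000 nM, with a range from 2500 nM to 45000 nM.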

Compound 4, half-maximal inhibitory concentration: 810 nM
The estimate for compound 4 lay 11-fold (1.05 log units) above the measured number, outside the stated range (below it).
By their numbers in this assay, from the lowest: compound 4; then compounds 2 and 1 (each within the scatter of the next); then compound 3.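

In this assay, replacing the chloro group on the aromatic carbon ortho to a large group and meta to a second chloro group with hydrogen gives a 5.1-fold lower number from compound 1 to compound 4 (0.71 log units; beyond the scatter), a step beyond the scatter towards a stronger inhibitor. Among these compounds, the only earlier step, a 190-fold higher number from compound 2 to compound 3 (2.29 log units; beyond the scatter), lay on the other aromatic ring and pointed towards a weaker inhibitor, so the two steps together show that a change in halogen pattern does not have the same outcome at every place. At this position the chloro group is not needed for the activity seen, and compound 4 keeps only the chloro group that stands meta to the position changed, yet no measurement at hand bears on why the number fell.

The compounds shown leave open whether hydrogen is the best choice at this position, or whether a fluoro group, a methyl group or an amine there would give a lower number still. They also leave open what the remaining chloro group contributes, and whether the same replacement would give a step of similar size on a core carrying a nitro group instead of the methoxy group.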